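Side chain removal at the alpha carbon of the ester

This account rests on a few compounds, and the source may have more. Where it says the series, first, only, none or still open, it means among the compounds named here.

Measured so far:
compound 1, `N=C(N)NCCC[C@H](NC(=O)CN(c1nc(Cl)nc2c1ncn2C1CCCCO1)C1CC1)C(=O)OCc1ccccc1`, 61.6%
compound 2, `NC(=O)C[C@H](NC(=O)CN(c1nc(Cl)nc2c1ncn2C1CCCCO1)C1CC1)C(=O)OCc1ccccc1`, 35%
compound 3, `NC(=O)CC[C@H](NC(=O)CN(c1nc(Cl)nc2c1ncn2C1CCCCO1)C1CC1)C(=O)OCc1ccccc1`, 37.8%

In a functional assay on the whole organism with Mus musculus as the target, with a stated time of 90 min, at a dose of 25 umol/kg by the oral route (on this read-out higher numbers stand for a stronger effect at the one dose given and lower numbers for a weaker effect), compound 1 gives 61.6%, the highest of the three numbers. Compound 3 stands second, with its nearest neighbour compound 2 within the scatter and compound 1 beyond it: a number 2.8 percentage points higher from compound 2 to compound 3 (within the scatter), while a number 23.8 percentage points lower from compound 1 to compound 3 (beyond the scatter). Compound 4, `O=C(CN(c1nc(Cl)nc2c1ncn2C1CCCCO1)C1CC1)NCC(=O)OCc1ccccc1`, is not yet measured. It differs from compound 3 in one place: hydrogen in place of 2-carbamoylethyl on a saturated chain carbon bound to an amide-type nitrogen and a carbonyl carbon.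

Among the compounds with values here, no measured step removes the side chain at this carbon altogether; the nearest guides are the two steps that shorten it. a number 26.6 percentage points lower from compound 1 to compound 2 (beyond the scatter) and a number 23.8 percentage points lower from compound 1 to compound 3 (beyond the scatter) both point downward when a smaller group stands there, whereas a number 2.8 percentage points higher from compound 2 to compound 3 (within the scatter) shows that the change from carbamoyl to carbamoylmethyl makes no difference beyond the scatter. Going from compound 3 to hydrogen is a further reduction, so the expectation for this assay is a modest fall, or at most a number within the scatter, but not a rise; the estimated step is a number 9.8 percentage points lower from compound 3 to compound 4 (within the scatter). Compound 4 is therefore expected to give about 28%, with a range from 10% to 48%.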

Compound 4, a percentage reported as activity, at one dose (the size of the read-out at that dose, not a potency): 25.9%
Compound 4: middle estimate off by 2.1 percentage points, on the high side, within the range that was stated.
By their numbers in this assay, from the lowest: compounds 4, 2 and 3 (each within the scatter of the next, the first and the last beyond it); then compound 1.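

In this assay, the full removal of the side chain gives a number 11.9 percentage points lower from compound 3 to compound 4 (beyond the scatter), so the 2-carbamoylethyl group makes a measurable contribution at this saturated chain carbon, whereas a number 9.1 percentage points lower from compound 2 to compound 4 (within the scatter) leaves the carbamoylmethyl group not distinguishable from hydrogen. Measured against the side chain of compound 1, hydrogen gives a number 35.7 percentage points lower from compound 1 to compound 4 (beyond the scatter), the widest span in the series at this carbon and a larger step than either of the two amide-bearing chains shows against compound 1. Even so, compound 4 still gives 25.9%, so a non-zero read-out at this dose does not require a side chain here, and the two amide-bearing chains add little or nothing clear beyond hydrogen compared with the side chain of compound 1.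

Nothing available on these compounds bears on the reason for these steps. From the compounds shown here alone, it remains open whether a primary amine or a carboxylic acid at the end of a chain, or a longer chain ending in carbamoyl, would come close to compound 1, and so whether the end group or the chain length governs the read-out at this carbon.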